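The source may hold more compounds than are shown below. What is called first, only, known or untested is meant among the compounds shown, and "the series" means these compounds.

Measured so far in a functional assay on EKVX cells (Homo sapiens) for inhibition; a lower number here means a stronger inhibitor of growth, a higher number a weaker inhibitor of growth:
compound 1 `C=C1CCC[C@H]2[C@](C)(CC[C@]3(C)CC[C@H]([C@@H](C)C(=O)O)OO3)[C@@H](C)CC[C@]12C` gives 1170 nM
compound 2 `C=C1CCC[C@H]2[C@](C)(CCC(C)=O)[C@@H](C)CC[C@]12C` gives a limit, > 15000 nM
compound 3 `CC1=C(CC/C(C)=C/CC[C@@]2(C)CC[C@@H]([C@H](C)C(=O)O)OO2)C(C)(C)CCC1` gives a limit, > 100000 nM

Compound 3 stands at the limit of > 100000 nM in this assay, at which 1 of the 3 values shown sits; this is a limit of the assay and not a number, so its distance to compound 1 cannot be sized. Compound 2 sits at the limit of > 15000 nM in this assay, at which 1 of the 3 values shown sits, likewise a limit. Among the compounds with values here, of the three, only compound 1 gives a number in this assay, and no step between measured compounds that differ in one place is at hand.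

Compound 4 `CC1=C(CC/C(C)=C/CC[C@@]2(C)CC[C@H]([C@H](C)C(=O)O)OO2)C(C)(C)CCC1` is to be measured in this assay. Compared with compound 3: the two compounds have the same atoms and bonds and differ only in configuration as drawn: 1 of 4 stereo elements differ; a stereocentre at a saturated ring carbon is drawn S in compound 3 and R in compound 4. Within the data shown here, no measured step shows what such a change of configuration does here, and with compound 3 at a limit the step can only be sized against that limit. The expectation is that the step of an at least 1.2-fold lower number from compound 3 to compound 4 (0.09 log units; that floor lies within the scatter) stays small, without any clear direction beyond the scatter, since the rest of compound 4 is unchanged from compound 3. Compound 4 is therefore estimated at 80000 nM, with a range from 20000 nM to 250000 nM, and a fair chance that this assay again reports only a limit.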

Compound 4, concentration for 50% growth inhibition: > 5000 nM
Compound 4 ended at the assay's limit; the forecaster's own chance of this, stated with the estimate: 60%; the middle value lies beyond the limit too.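

In this assay compound 3 gives > 100000 nM, a limit and not a number. Within the data shown here, compound 4 gives > 5000 nM, likewise a limit, and no step between compound 3 and compound 4 can be read. The compounds shown leave open whether the change of configuration at the saturated ring carbon alters growth inhibition at all, and in which direction.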